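Working notes: 3-chlorophenyl in place of 4-methylphenyl

The source may report more compounds than this note shows. Statements on the series, on what has been measured and on what is new or still open speak of the compounds shown alone.

Measured in a functional assay on MDA-MB-231 cells (Homo sapiens) for antiproliferative activity, read by MTT assay, with a stated time of 24 h; a higher number here means a weaker inhibitor, a lower number a stronger inhibitor:
compound 1 `O=C(NNc1ccccc1F)c1cccc(NS(=O)(=O)c2cnc(O)nc2O)c1`: > 20000 nM (a limit)
compound 2 `Cc1ccccc1C(=O)NNC(=O)c1cccc(NS(=O)(=O)c2cnc(O)nc2O)c1`: 18100 nM
compound 3 `Cc1ccc(C(=O)NNC(=O)c2cccc(NS(=O)(=O)c3cnc(O)nc3O)c2)cc1`: > 20000 nM (a limit)

Compound 3 has no number in this assay, only the limit > 20000 nM. That places compound 3 at the limit of > 20000 nM in this assay, at which 2 of the 3 values shown sit. For the measured compounds named here, the only number so far belongs to compound 2, at 18100 nM.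

Compound 4 `O=C(NNC(=O)c1cccc(NS(=O)(=O)c2cnc(O)nc2O)c1)c1cccc(Cl)c1` keeps the shared core and differs from compound 3 in one group: 3-chlorophenyl in place of 4-methylphenyl on a carbonyl carbon. The change is 3-chlorophenyl in place of 4-methylphenyl on a carbonyl carbon.

The closest measured step, an at least 1.1-fold higher number from compound 2 to compound 3 (0.04 log units; that floor lies within the scatter), exchanges 2-methylphenyl for 4-methylphenyl at that same carbonyl carbon. The other readable step, an at least 1.1-fold lower number from compound 1 to compound 2 (0.04 log units; that floor lies within the scatter), is also a floor set by a limit. The step that the two limits leave unreadable from compound 1 to compound 3 joins two limits and gives no size. Going by the values given here, no measured step therefore shows a change beyond the scatter, and none beyond the scatter is expected here in this assay. The direction cannot be read from these data. The expected step is a step that the limit leaves unreadable from compound 3 to compound 4. A report as a limit is expected to be more likely than a number. Compound 4 is estimated at 22000 nM, with an expected range from 12000 nM to 40000 nM.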

Compound 4, half-maximal inhibitory concentration: 3180 nM
Estimate against measurement, compound 4: 6.9-fold (0.84 log units) above; the measured number lies below the stated range.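

In this assay, the carbonyl carbon had shown no step beyond the scatter until now, and 3-chlorophenyl in place of 4-methylphenyl gives an at least 6.2-fold lower number from compound 3 to compound 4 (0.79 log units; beyond the scatter). With 3-chlorophenyl in place of 2-methylphenyl at the same carbon, the series has its first step between two actual numbers that lies beyond the scatter, a 5.7-fold lower number from compound 2 to compound 4 (0.76 log units; beyond the scatter), while (3-chlorophenyl)carbonyl in place of 2-fluorophenyl on an amine nitrogen gives an at least 6.2-fold lower number from compound 1 to compound 4 (0.79 log units; beyond the scatter). Compound 4 therefore stands apart from all three earlier compounds as the strongest inhibitor shown, though two of these steps give only a floor and not a full size: the limit of > 20000 nM in this assay, at which 2 of the 4 values shown sit.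

The exchange in compound 4 alters both the substituent and its place on the phenyl ring, so the compounds shown do not separate the contribution of the chlorine from that of its place, a question that 3-methylphenyl and 4-chlorophenyl on the same carbonyl carbon would bear on. Also open, as far as these compounds go, is how far the step extends to other groups on that ring, such as 3-bromophenyl or 3-methoxyphenyl.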